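Side-chain change from compound 1 to compound 3

The source may hold more compounds than are shown below. What is called first, only, known or untested is meant among the compounds shown, and "the series" means these compounds.

In a functional assay on the whole organism for inhibition, with Cavia porcellus as the target (a higher number here means that more compound is needed for the effect, a lower number that less compound is needed), compound 1 `CCCC(=O)CC(=O)N1CCSC1COc1ccccc1OC` gives 42 mg/kg and compound 2 `CCOC(=O)CCC(=O)N1CCSC1COc1ccccc1OC` gives 24 mg/kg, two numbers within the scatter of each other. Compound 3 `CCN(CC)CCNC(=O)CC(=O)N1CCSC1COc1ccccc1OC` has (2-(diethylamino)ethyl)amino in place of propyl on a carbonyl carbon. Going by the values given here, the only measured step, a 1.8-fold lower number from compound 1 to compound 2 (0.24 log units; within the scatter), alters the same side chain at another place and stays within the scatter. Among the compounds with values here, no measured compound carries the entering group, so that step is weak guidance and no direction can be assigned. The expected change is a 1.1-fold lower number from compound 1 to compound 3 (0.02 log units; within the scatter), nothing beyond the scatter. For compound 3 the estimate is 40 mg/kg, with an expected range of 15 mg/kg to 100 mg/kg.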

Compound 3, dose for half-maximal effect: 56 mg/kg
The estimate for compound 3 lay 1.4-fold (0.15 log units) below the measured number, and the stated range covers the measured number.
By their numbers in this assay, from the lowest: compounds 2, 1 and 3 (each within the scatter of the next, the first and the last beyond it).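

In this assay, (2-(diethylamino)ethyl)amino in place of propyl on a carbonyl carbon gives a 1.3-fold higher number from compound 1 to compound 3 (0.12 log units; within the scatter). This carbonyl carbon therefore accepts a far larger group carrying a hydrogen-bond donor and acceptor, with no shift beyond the scatter, which the earlier pair could not show. Nothing available bears on the cause of this outcome.

Still open, from the compounds shown here alone, is whether a carboxylic acid, a simple primary amine or a longer alkyl chain on this carbonyl carbon would move the number beyond the scatter.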